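Larger Polar Substituent in Place of Methyl on the Fused Ring

The compounds below may be only part of what the source reports. "The series", "measured", "known", "first", "only" and "open" are said of these compounds alone.

Compound 2 `Cc1cc2nccc(-c3cc(Cl)cc4c3O[C@@H](C(=O)N3CCNCC3)C4)c2s1` holds the lower of the two numbers measured in an assay on isolated protein for inhibition of ubiquitin carboxyl-terminal hydrolase 7 (Homo sapiens), read by fluorescence, with stated times of 30 min and 1 h; a higher number here means a weaker inhibitor, a lower number a stronger inhibitor: compound 2 gives 130 nM, whereas compound 1 `O=C([C@H]1Cc2cc(Cl)cc(-c3ccnc4[nH]ccc34)c2O1)N1CCNCC1` gives 450 nM in this assay, a gap that lies beyond the usual scatter. Compound 3 `O=C([C@H]1Cc2cc(Cl)cc(-c3ccnc4cc(C(O)(CO)CCl)sc34)c2O1)N1CCNCC1` has not yet been measured. It differs from compound 2 by 1-(chloromethyl)-1,2-dihydroxyethyl in place of methyl on an aromatic carbon. No single-place change between measured compounds exists to gauge such a swap, so only a modest step is anticipated, likely within or just beyond the scatter, with direction uncertain. The expected step is a 1.7-fold higher number from compound 2 to compound 3 (0.23 log units; within the scatter). Compound 3 is estimated at 220 nM, between 70 nM and 700 nM.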

Compound 3, half-maximal inhibitory concentration: 9 nM
For compound 3 the middle estimate is 24-fold (1.39 log units) above the measured one, and the stated range ends above it.
By their numbers in this assay, from the lowest: compound 3; then compound 2; then compound 1.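

In this assay, methyl gives way to 1-(chloromethyl)-1,2-dihydroxyethyl on the aromatic carbon next to the ring sulfur, with a 14-fold lower number from compound 2 to compound 3 (1.16 log units; beyond the scatter) as the result. This shows that the position accepts a much larger group and that a change here can lower the number far beyond the scatter. Nothing at hand explains the size of this step. Going by these compounds, it stays open whether the chlorine, the two hydroxyl groups or the whole chain accounts for the step. On these data alone, how a hydroxymethyl, an amine or a carboxylic acid would fare at this position also stays open.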